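The compounds below may be only part of what the source reports. "The series", "measured", "known", "first", "only" and "open" are said of these compounds alone.

Measured compounds in a functional assay on HCT-116 cells (Homo sapiens) for antiproliferative activity, read by MTT assay; on this read-out lower numbers stand for stronger inhibition and higher numbers for weaker inhibition:
- compound 1, `Cn1c(=O)c(=O)n(C2CCCC2)c2nc(N/N=C/c3ccc(F)c(Cl)c3)ncc21`, gives 9020 nM
- compound 2, `Cn1c(=O)c(=O)n(C2CCCC2)c2nc(N/N=C/c3cccc(Cl)c3Cl)ncc21`, gives 26400 nM
- compound 3, `COc1ccc(/C=N/Nc2ncc3c(n2)n(C2CCCC2)c(=O)c(=O)n3C)cc1`, gives 36100 nM

Compound 1 holds the lowest number of the three in this assay. The two other aryl groups on the carbon with a double bond to nitrogen both push the number up: a 2.9-fold higher number from compound 1 to compound 2 (0.47 log units; beyond the scatter) and a 4.0-fold higher number from compound 1 to compound 3 (0.60 log units; beyond the scatter). Between compound 2 and compound 3 the gap is small: a 1.4-fold higher number from compound 2 to compound 3 (0.14 log units; within the scatter).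

Compound 4, `Cn1c(=O)c(=O)n(C2CCCC2)c2nc(N/N=C/c3ccc(F)cc3Br)ncc21`, has not been measured. It differs from compound 1 as follows: 2-bromo-4-fluorophenyl in place of 3-chloro-4-fluorophenyl on a carbon with a double bond to nitrogen. Among the measured compounds shown here, only the steps from compound 1 to compound 2 and from compound 1 to compound 3 bear on this change, and both were modest moves toward weaker inhibition when the halogen pattern or substituent on that ring was altered. A step of similar kind, upward but modest, is therefore expected for compound 4 in this assay, roughly a 1.8-fold higher number from compound 1 to compound 4 (0.25 log units; within the scatter). Compound 4 is estimated at 16000 nM, with a range from 6000 nM to 40000 nM.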

Compound 4, half-maximal inhibitory concentration: 8390 nM
Compound 4: the middle estimate sits 1.9-fold (0.28 log units) above what was measured; the measured number falls inside the stated range.
By their numbers in this assay, from the lowest: compounds 4 and 1 (each within the scatter of the next); then compounds 2 and 3 (each within the scatter of the next).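

In this assay, among the compounds shown here, 2-bromo-4-fluorophenyl on the carbon with a double bond to nitrogen gives a 1.1-fold lower number from compound 1 to compound 4 (0.03 log units; within the scatter) and so matches 3-chloro-4-fluorophenyl, the first change at this position that does not raise the number and a sign that the halogen pattern here can shift without loss. The same group also stands clear of the two other aryl groups, with a 4.3-fold lower number from compound 3 to compound 4 (0.63 log units; beyond the scatter) and a 3.1-fold lower number from compound 2 to compound 4 (0.50 log units; beyond the scatter), so among these four compounds the two with a fluorine named at ring position 4 and a second halogen hold the lowest numbers, while two chlorines alone in compound 2 do not reach them. No measurement at hand accounts for these differences.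

Open, going by these compounds, is whether 4-fluorophenyl alone would hold this level, without the bromine or chlorine. Also open, on these data alone, is how an amine or a carboxylic acid on this ring would read.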